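The source may hold more compounds than are shown below. What is called first, only, known or untested is meant among the compounds shown, and "the series" means these compounds.

Measured compounds in a functional assay on HeLa cells (Homo sapiens) for cytotoxicity, read by MTT assay, with a stated time of 48 h; a lower number here means a stronger inhibitor, a higher number a weaker inhibitor:
Compound 1 `CCN(CC)c1ccc2cc(C(=O)c3ccc(N4CCN(C(=O)CN5CCNCC5)CC4)cc3)oc2c1`; compound 1 gives 1350 nM.
Compound 2 `CCN(CC)c1ccc2cc(C(=O)c3ccc(N4CCN(C(=O)CN5CCN(C(=O)/C=C/c6ccccc6)CC5)CC4)cc3)oc2c1`; compound 2 gives 5260 nM.
Compound 3 `CCN(CC)c1ccc2cc(C(=O)c3ccc(N4CCN(C(=O)CN5CCN(S(=O)(=O)c6ccc(C(F)(F)F)cc6)CC5)CC4)cc3)oc2c1`; compound 3 reaches only a limit of the assay, > 40000 nM.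

Compound 2 holds the higher of the two numbers that were obtained. Among the measured compounds shown here, its nearest neighbour is compound 1, and the single measured step between them is a 3.9-fold higher number from compound 1 to compound 2 (0.59 log units; beyond the scatter), a modest rise that came with the (2-phenylethenyl)carbonyl group on the ring nitrogen. Compound 3, which carries a sulfonyl group on that same nitrogen, sits at the limit of > 40000 nM in this assay, at which 1 of the 3 values shown sits.

Compound 4 `CCN(CC)c1ccc2cc(C(=O)c3ccc(N4CCN(C(=O)CN5CCN(Cc6ccc(F)c(F)c6)CC5)CC4)cc3)oc2c1` is the next compound to be measured. It differs from compound 2 by 3,4-difluorobenzyl in place of (2-phenylethenyl)carbonyl on an amine nitrogen in a ring. For the measured compounds named here, only the step of a 3.9-fold higher number from compound 1 to compound 2 (0.59 log units; beyond the scatter) bears directly on this nitrogen, and it shows that placing the (2-phenylethenyl)carbonyl there raised the number. In compound 4 that carbonyl-bearing group leaves and a 3,4-difluorobenzyl group enters; the change thus undoes part of what separated compound 2 from compound 1, while adding a new ring. A small fall in the number is therefore expected, though it may stay within the scatter. Compound 4 is expected to give about 2500 nM in this assay, between 900 nM and 7000 nM, which is a 2.1-fold lower number from compound 2 to compound 4 (0.32 log units; beyond the scatter).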

Compound 4, half-maximal inhibitory concentration: 6400 nM
Estimate against measurement, compound 4: 2.6-fold (0.41 log units) below, within the range that was stated.
By their numbers in this assay, from the lowest: compound 1; then compounds 2 and 4 (each within the scatter of the next). At a limit, above all of these: compound 3.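

In this assay, the result is a 1.2-fold higher number from compound 2 to compound 4 (0.09 log units; within the scatter), so on this ring nitrogen the 3,4-difluorobenzyl and (2-phenylethenyl)carbonyl groups cannot be told apart, and a carbonyl on this nitrogen is not needed for a number of this size. Against hydrogen on the same nitrogen, the result is a 4.7-fold higher number from compound 1 to compound 4 (0.68 log units; beyond the scatter), and the earlier step was a 3.9-fold higher number from compound 1 to compound 2 (0.59 log units; beyond the scatter), so two different groups, each bringing a six-membered aromatic ring, now go the same way, to a higher number than compound 1. Compound 3, with its sulfonyl group on this nitrogen, fits that direction only loosely, since it gives a limit of the assay and not a number: the limit of > 40000 nM in this assay, at which 1 of the 4 values shown sits.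

The compounds shown leave open whether a small group such as methyl on this nitrogen would give a number close to that of compound 1 or close to those of compound 2 and compound 4. They also leave open what the fluorines contribute, which a plain benzyl group could show, and whether a saturated group such as cyclohexylmethyl would match compound 4.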